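The compounds below may be only part of what the source reports. "The series", "measured", "known", "first", "only" and "open" are said of these compounds alone.

Compound 1 `Cc1ccc2c(NCc3ccc(NC(=O)C4CCN(Cc5ccc(F)cc5)CC4)cc3)nc(N(C)C)nc2c1` — > 4820 nM
Compound 2 `Cc1ccc2c(NCc3ccc(NC(=O)C4CCN(Cc5ccccc5)CC4)cc3)nc(N3CCC3)nc2c1` — > 8500 nM
Compound 3 `COc1ccc(CN2CCC(C(=O)Nc3ccc(CNc4nc(N(C)C)nc5cc(C)ccc45)cc3)CC2)cc1` — > 6180 nM

In a functional assay on SV5A8 cells (Homo sapiens) for cytotoxicity (a lower number here means a stronger inhibitor, a higher number a weaker inhibitor), compound 3 gives only > 6180 nM, which is a limit of the assay and not a number. Its two neighbours fare no differently: compound 1 returns > 4820 nM as a limit, and compound 2 returns > 8500 nM as a limit. For the measured compounds named here, all three values shown are therefore limits, as the limit of > 4820 nM in this assay, at which 1 of the 3 values shown sits, the limit of > 6180 nM in this assay, at which 1 of the 3 values shown sits, and the limit of > 8500 nM in this assay, at which 1 of the 3 values shown sits, record, and no measured step among them is readable; in particular the change of methoxy in place of fluoro on an aromatic carbon gives a step that the two limits leave unreadable from compound 1 to compound 3.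

Compound 4 `Cc1ccc2c(NCc3ccc(NC(=O)C4CCN(Cc5ccccc5F)CC4)cc3)nc(N(C)C)nc2c1` differs from compound 3 by 2-fluorophenyl in place of 4-methoxyphenyl on a saturated chain carbon bound to an amine nitrogen in a ring. Going by the values given here, the only measured step that bears on this kind of change is the one from compound 1 to compound 3, and it cannot be sized, since both of its ends sit at limits. What the three limits do show is that every variation of the group on the saturated chain carbon bound to the ring amine nitrogen so far has left this assay without a number, and compound 4 is expected to follow that pattern rather than break it. Compound 4 is thus estimated at 9000 nM in this assay, with a range from 3000 nM to 40000 nM, most probably reported again only as a limit. The step from compound 3 to compound 4 is expected to be a step that the limit leaves unreadable from compound 3 to compound 4, no change that the scatter could distinguish.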

Compound 4, half-maximal inhibitory concentration: > 6670 nM
Compound 4: only a limit was reported; the forecaster's own chance of this, stated with the estimate: 80%; the middle value lies beyond the limit too.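

In this assay compound 4 again gives only a limit of the assay and not a number, so its steps from compound 3 and from compound 1 cannot be read. The compounds shown leave open whether exchanging the group on the saturated chain carbon bound to an amine nitrogen in a ring changes the result in this assay at all.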